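The compounds below may be only part of what the source reports. "The series", "measured", "known", "first", "only" and "open" are said of these compounds alone.

Going by the values given here, in a functional assay on KB cells (Homo sapiens) for inhibition, read by MTT assay, with a stated time of 24 h, tested at 10 ug/mL (on this read-out higher numbers stand for more inhibition of growth at the one concentration tested and lower numbers for less inhibition of growth), compound 1 (`O=C(CCCCC1CCSS1)Nc1ccc(OC(F)(F)F)cc1`) gives 8.49% as the only number so far, and compound 2 (`O=C(CCCCC1CCSS1)Nc1cccc2ccccc12`) is reported as "not active" (no number reported) with no value attached. Compound 3 (`O=C(CCCCC(S)CCS)Nc1ccc(OC(F)(F)F)cc1`) carries one change from compound 1: a group of 5 heavy atoms (3 carbon, 2 sulfur; no ring) in place of a group of 5 heavy atoms (3 carbon, 2 sulfur; one five-membered non-aromatic ring with 2 hetero atoms), on a saturated chain carbon, four bonds along the chain from a carbonyl carbon with 1,3-disulfanylpropyl as the entering group and no ring left at that place. Among the compounds with values here, no measured pair shows such a change, so the estimated a number 1.5 percentage points higher from compound 1 to compound 3 (within the scatter) is expected to stay within the usual scatter in this assay with no direction favoured. For compound 3 the expected value is 10% within an estimated range of 2% to 22% for the coming measurement.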

Compound 3, percent growth inhibition at one concentration: 15%
Estimate against measurement, compound 3: 5 percentage points below, and the stated range covers the measured number.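

Replacing the five-membered ring with 1,3-disulfanylpropyl, on a saturated chain carbon, four bonds along the chain from a carbonyl carbon, gives in this assay a number 6.5 percentage points higher from compound 1 to compound 3 (within the scatter). Going by these compounds alone, this is the first readable step, and at this place the ring and the open chain are not separated by this read-out. No available evidence bears on the result.

On these data alone, whether a carboxylic acid or a longer chain at this place would give a step beyond the scatter stays open. So does the effect of the same ring opening on compound 2, which has no number.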